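This account rests on a few compounds, and the source may have more. Where it says the series, first, only, none or still open, it means among the compounds named here.

Working notes on the series. For the measured compounds named here, the shared core is carried by compound 2 `COc1cc(N(Cc2ccc(C)cc2)C(=O)CSc2nc3ccccc3s2)cc(OC)c1OC`, which in a functional assay on MGC-803 cells (Homo sapiens) for antiproliferative activity, read by MTT assay, with a stated time of 48 h (a higher number here means a weaker inhibitor, a lower number a stronger inhibitor), gives 54200 nM, the highest of the three numbers measured so far. Compound 1 `COc1ccc(CN(C(=O)CSc2nc3cc(Br)ccc3s2)c2cc(OC)c(OC)c(OC)c2)cc1O` gives 372 nM and compound 3 `COc1ccc(CN(C(=O)CSc2nc3c(C)cccc3s2)c2cc(OC)c(OC)c(OC)c2)cc1O` gives 493 nM; both lie far beyond the scatter from compound 2, and both differ from it in two places at once, on the benzyl group and on the group attached to the sulfur. Going by the values given here, the one single-point step measured, a 1.3-fold higher number from compound 1 to compound 3 (0.12 log units; within the scatter), shows that exchanging the group on the sulfur changes little. Compound 4 `COc1ccc(CN(C(=O)CSc2nc3ccccc3s2)c2cc(OC)c(OC)c(OC)c2)cc1` has not been measured; against compound 2 the change is methoxy in place of methyl on an aromatic carbon. Among the compounds with values here, no measured step exchanges methyl for methoxy on the benzyl ring, so the size of the step cannot be read directly; the gap between compound 2 and compounds 1 and 3 only shows that substitution on this ring, together with the sulfur group, spans a wide range. The step is therefore expected to run toward a lower number, as a 6.8-fold lower number from compound 2 to compound 4 (0.83 log units; beyond the scatter), though with wide uncertainty. Compound 4 is estimated at 8000 nM, within 1500 nM to 40000 nM.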

Compound 4, half-maximal inhibitory concentration: 163 nM
The estimate for compound 4 lay 49-fold (1.69 log units) above the measured number, outside the stated range (below it).
By their numbers in this assay, from the lowest: compound 4; then compounds 1 and 3 (each within the scatter of the next); then compound 2.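

In this assay, the exchange of 4-methylbenzyl for 4-methoxybenzyl alone gives a 330-fold lower number from compound 2 to compound 4 (2.52 log units; beyond the scatter), so a large step can be assigned to this one position and this one change. The earlier gap between compound 2 and compounds 1 and 3 could not show this, as those pairs differ in two places at once. For the compounds shown here, the step also stands in contrast to the only other single-place step, a 1.3-fold higher number from compound 1 to compound 3 (0.12 log units; within the scatter), which lies within the scatter and concerns the group on the sulfur. Nothing measured here bears on the origin of the step at the benzyl ring.

It remains open whether ethoxy, fluorine or a dimethylamino group on the same aromatic carbon would fall with methoxy, with methyl or elsewhere, so the compounds shown do not separate the role of the oxygen from that of the added atom. From the compounds shown here alone, it also remains open whether the step keeps its size when the group on the sulfur is the bromine-bearing one of compound 1 or the methyl-bearing one of compound 3.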